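Shortening the ester side chain of compound 3

The source may hold more compounds than are shown below. What is called first, only, known or untested is meant among the compounds shown, and "the series" means these compounds.

Compound 1 `N=C(N)NCCC[C@H](NC(=O)CN(c1ncnc2c1ncn2C1CCCCO1)C1CC1)C(=O)OCc1ccccc1`: 34.3%
Compound 2 `NC(=O)CC[C@H](NC(=O)CN(c1ncnc2c1ncn2C1CCCCO1)C1CC1)C(=O)OCc1ccccc1`: 47%
Compound 3 `O=C(CN(c1ncnc2c1ncn2C1CCCCO1)C1CC1)N[C@@H](CCC(=O)OCc1ccccc1)C(=O)OCc1ccccc1`: 32.6%

In a functional assay on the whole organism (Tail, strain ICR) with Mus musculus as the target, in the tail flick test, with a stated time of 30 min, at a dose of 25 umol/kg by the oral route (a higher number here means a stronger effect of the compound at the dose given, a lower number a weaker effect), compound 3 gives 32.6%, the lowest of the three numbers. It sits close to compound 1, the step being a number 1.7 percentage points lower from compound 1 to compound 3 (within the scatter), while the step of a number 14.4 percentage points lower from compound 2 to compound 3 (beyond the scatter) is beyond the scatter. Compound 4 `O=C(CN(c1ncnc2c1ncn2C1CCCCO1)C1CC1)N[C@@H](CC(=O)OCc1ccccc1)C(=O)OCc1ccccc1` differs from compound 3 in one place: benzyloxycarbonyl in place of (benzyloxycarbonyl)methyl on a saturated chain carbon, two bonds along the chain from an amide-type nitrogen and a carbonyl carbon. Both measured steps changed the group on the side chain, not its length, so neither bears directly on this change; the two steps were one within the scatter and one modest. The expected step is therefore a number 0.4 percentage points higher from compound 3 to compound 4 (within the scatter), with no movement beyond the scatter. Compound 4 is estimated at 33%, within a range from 20% to 46%.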

Compound 4, a percentage reported as activity, at one dose (the size of the read-out at that dose, not a potency): 31.8%
Beside the measured number, compound 4's estimate is 1.2 percentage points above it; low and high end bracket the measured number.
By their numbers in this assay, from the lowest: compounds 4, 3 and 1 (each within the scatter of the next); then compound 2.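

Among the compounds shown, this is the only step that changes the chain length alone, and in this assay going from 2-(benzyloxycarbonyl)ethyl to (benzyloxycarbonyl)methyl gives a number 0.8 percentage points lower from compound 3 to compound 4 (within the scatter), so the shorter ester holds the number. The new compound also shows a number 2.5 percentage points lower from compound 1 to compound 4 (within the scatter), while the amide-bearing side chain stays apart, with a number 15.2 percentage points lower from compound 2 to compound 4 (beyond the scatter). Nothing available explains these numbers.

From the compounds shown here alone, whether a carboxylic acid or an amine on this chain would change the number remains open. So does the effect of a longer chain carrying the benzyl ester.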